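The source may hold more compounds than are shown below. What is called first, only, known or untested is meant among the compounds shown, and "the series" means these compounds.

Of the compounds shown here, two from this series have been measured so far. Compound 1 `COc1ccccc1N1CCN(CCCNC(=O)CCc2c[nH]c3ccccc23)CC1` carries a three-carbon chain from its indole to the amide, while compound 2 `COc1ccc2[nH]c(C(=O)NCCCN3CCN(c4ccccc4OC)CC3)cc2c1` has the carbonyl attached directly to the indole and bears a methoxy on the benzene part of that fused ring. In an assay on isolated protein (spleen, strain Sprague-Dawley) for antagonist activity at Alpha-1B adrenergic receptor (Rattus norvegicus), with a stated time of 20 min (on this read-out higher numbers stand for weaker binding and lower numbers for tighter binding), compound 1 gives 219 nM. In this assay compound 2 gives 1450 nM, the higher of the two numbers, and the gap between compound 2 and compound 1 lies beyond the usual scatter of repeated measurements.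

Compound 3 `COc1ccccc1N1CCN(CCCNC(=O)c2cc3cc(Cl)ccc3[nH]2)CC1` keeps the whole skeleton of compound 2 and changes only one substituent: chloro in place of methoxy on an aromatic carbon. Within the data shown here, no measured pair in this set shows what such a swap does at that position, so there is no reference step to lean on. Compound 3 is therefore expected to stay close to compound 2, with a step of a 1.5-fold lower number from compound 2 to compound 3 (0.16 log units; within the scatter) that need not exceed the scatter in either direction. For compound 3 the expected value in this assay is 1000 nM, with a range from 350 nM to 3000 nM.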

Compound 3, dissociation constant: 257 nM
Compound 3: middle estimate off by 3.9-fold (0.59 log units), on the high side, outside the stated range (below it).
By their numbers in this assay, from the lowest: compounds 1 and 3 (each within the scatter of the next); then compound 2.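

Read in this assay the swap of methoxy for chloro on an otherwise unchanged skeleton gives a 5.6-fold lower number from compound 2 to compound 3 (0.75 log units; beyond the scatter) and is the first comparison here in which only one place differs. It shows that this aromatic carbon, meta to a fused ring and para to a fused ring, is not a silent spot: the choice of group there can by itself change the binding number, and here chloro goes with the tighter binding. Nothing available here accounts for the size or direction of this step, so it stands as an observation without an explanation.

The compounds shown leave open how a hydrogen, a fluoro, a bromo or a trifluoromethyl on this same carbon would compare with chloro and methoxy, so a single pair cannot yet show a trend across groups. They also leave open whether the same swap of methoxy for chloro would give a step of similar size when a longer chain joins the amide to the fused ring system.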